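Adding to the methyl of compound 3

The source may hold more compounds than are shown below. What is called first, only, known or untested is meant among the compounds shown, and "the series" means these compounds.

Compound 1 `CCNC(=O)CCc1cccc2c1B(O)OC2`: > 100000 nM (a limit)
Compound 2 `CC(C)(C)NC(=O)CCc1cccc2c1B(O)OC2`: > 100000 nM (a limit)
Compound 3 `Cc1ccc(NC(=O)CCc2cccc3c2B(O)OC3)cc1`: 1100 nM

Among the measured compounds shown here, in a functional assay on MDA-MB-231 cells (Homo sapiens) for antiproliferative activity, read by MTT assay, with a stated time of 72 h (on this read-out lower numbers stand for stronger inhibition and higher numbers for weaker inhibition), compound 3 gives 1100 nM as the only true number here. Compound 1 and compound 2 each stand at a limit. The measured steps that matter are an at least 90-fold lower number from compound 1 to compound 3 (1.95 log units; beyond the scatter) and an at least 90-fold lower number from compound 2 to compound 3 (1.95 log units; beyond the scatter) and both are large, but both change the group on the amide nitrogen. Compound 4 `CC(C)(C)OC(=O)NCc1ccc(NC(=O)CCc2cccc3c2B(O)OC3)cc1` keeps the 4-methylphenyl of compound 3 and carries (tert-butoxycarbonyl)amino in place of hydrogen on a saturated chain carbon bound to an aromatic carbon as its one difference. For the measured compounds named here, no measured step tests this place, so compound 3 at 1100 nM remains the only anchor. In this assay the expected change is a 1.6-fold higher number from compound 3 to compound 4 (0.21 log units; within the scatter) and no step beyond the scatter is foreseen. For compound 4 the estimated value is 1800 nM (expected range 350 nM to 9000 nM).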

Compound 4, half-maximal inhibitory concentration: 1300 nM
Compound 4: middle estimate off by 1.4-fold (0.14 log units), on the high side; measured number inside the range.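

In this assay, placing (tert-butoxycarbonyl)amino on a saturated chain carbon bound to an aromatic carbon gives a 1.2-fold higher number from compound 3 to compound 4 (0.07 log units; within the scatter), so the two numbers cannot be told apart. The earlier compounds shown here left this place untested; it now proves able to carry this group of 8 heavy atoms without a step beyond the scatter. Nothing measured here explains this result. On these data alone, whether a free amine or a carboxylic acid would fare the same at this place stays open. So does a longer chain.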